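The source may hold more compounds than are shown below. What is called first, only, known or untested is meant among the compounds shown, and "the series" means these compounds.

The two compounds measured share one core and are tested in a functional assay on RPMI-8226 cells (Homo sapiens) for cytotoxicity, read by sulforhodamine B assay, with a stated time of 48 h, tested at 1 uM; a higher number here means a weaker effect of the compound at the concentration tested, a lower number a stronger effect. Going by the values given here, compound 1 `COc1ccc(C(=O)/C=C/c2cc(-c3cc(OC)c(OC)c(OC)c3)n[nH]2)cc1OC` gives 2% in this assay, the lowest of the two numbers known, while compound 2 `COc1cc(-c2cc(/C=C/C(=O)c3ccc(F)c(F)c3)[nH]n2)cc(OC)c1OC` gives 73%. Among the compounds with values here, the single known step, a number 71 percentage points higher from compound 1 to compound 2 (beyond the scatter), is a large loss of effect that follows the exchange of 3,4-dimethoxyphenyl for 3,4-difluorophenyl on a carbonyl carbon. Compound 3 `COc1cc(C(=O)/C=C/c2cc(-c3cc(OC)c(OC)c(OC)c3)n[nH]2)cc(OC)c1OC` differs from compound 1 by methoxy in place of hydrogen on an aromatic carbon. Within the data shown here, no measured step shows a methoxy entering in place of hydrogen; the step from compound 1 to compound 2 replaces a whole aryl group and so bears only loosely on the present change. For compound 3 the expected step is a number 8 percentage points higher from compound 1 to compound 3 (within the scatter), a shift that may well stay within the scatter. Compound 3 is therefore estimated to give 10% in this assay, with a range from 0% to 45%.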

Compound 3, a percentage reported as activity, at one concentration (the size of the read-out at that concentration, not a potency): 17%
Beside the measured number, compound 3's estimate is 7 percentage points below it; measured number inside the range.
By their numbers in this assay, from the lowest: compound 1; then compound 3; then compound 2.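

The first measured entry of a methoxy in place of hydrogen on this ring gives a number 15 percentage points higher from compound 1 to compound 3 (beyond the scatter) in this assay, so the added group, ortho to a methoxy group and meta to a large group, does cost some effect, though the step is only modest. Set against a number 71 percentage points higher from compound 1 to compound 2 (beyond the scatter), which follows the exchange of a whole aryl group, this shows that the ring on the carbonyl carbon takes one more methoxy with a much smaller loss of effect. Nothing available bears on the cause of this step.

The compounds shown leave open whether a hydroxy group or an amine on this same aromatic carbon would stay near compound 1 or move further from it. Also open, going by these compounds, is whether a longer chain such as ethoxy would be tolerated there as well as methoxy.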